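Chloro count on the carboxy-bearing ring in this series

A few compounds are considered here, and "the series" means these few. Any claim that something is new, unique, unknown or untested is made for them only; others in the source may bear on it.

Measured so far:
compound 1, `CC(C)N(C(=O)COc1ccc(-c2ccc(C(=O)O)cc2)cc1)C(C)C`, 830 nM
compound 2, `CC(C)N(C(=O)COc1ccc(-c2c(Cl)cc(C(=O)O)cc2Cl)cc1)C(C)C`, > 10000 nM

In an assay on Prostate gland for inhibition of 3-oxo-5-alpha-steroid 4-dehydrogenase 2 (Homo sapiens) (a higher number here means a weaker inhibitor, a lower number a stronger inhibitor), compound 1 gives 830 nM. For compound 2 the reading in this assay is only a limit, > 10000 nM, and this sits at the limit of > 10000 nM in this assay, at which 1 of the 2 values shown sits. Compound 2 therefore stands at the weak end of what is shown, with no number of its own, while compound 1 has a measured value.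

Compound 3, `CC(C)N(C(=O)COc1ccc(-c2ccc(C(=O)O)cc2Cl)cc1)C(C)C`, differs from compound 2 by hydrogen in place of chloro on an aromatic carbon; compound 3 keeps one chloro. Within the data shown here, no step between measured compounds bears on this change directly. Since compound 1 carries no chloro and is measured, and compound 2 with two chloro groups reaches only a limit, the step from compound 2 to compound 3 is expected to be an at least 3.3-fold lower number from compound 2 to compound 3 (0.52 log units; beyond the scatter), a gain beyond the scatter. Compound 3 is estimated at 3000 nM, within 1000 nM to 10000 nM.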

Compound 3, half-maximal inhibitory concentration: 870 nM
Compound 3: middle estimate off by 3.4-fold (0.54 log units), on the high side, and the stated range ends above it.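

With one chloro on the carboxy-bearing ring, this assay shows a 1.0-fold higher number from compound 1 to compound 3 (0.02 log units; within the scatter), so a single chloro carries no measurable cost. The sharp loss comes only with the second chloro, on the aromatic carbon ortho to a large group and meta to a carboxy group, and removing it gives an at least 11-fold lower number from compound 2 to compound 3 (1.06 log units; beyond the scatter). Compound 2 has no number of its own, only a limit: the limit of > 10000 nM in this assay, at which 1 of the 3 values shown sits.

From the compounds shown here alone, it remains open whether the loss depends on chloro itself or on any group at that second place, as a fluoro or a methyl group there would show. Also open, going by these compounds, is whether the tolerance of one chloro would persist with a tetrazole in place of the carboxy group.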